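The source may report more compounds than this note shows. Statements on the series, on what has been measured and on what is new or still open speak of the compounds shown alone.

Measured so far:
compound 1, `Cc1c(C(=O)Nc2nnn[nH]2)oc2ccccc2c1=O`, 0.4 ug/mL
compound 2, `Cc1ccc2oc(C(=O)Nc3nnn[nH]3)cc(=O)c2c1`, 0.075 ug/mL
compound 3, `O=C(Nc1nnn[nH]1)c1oc2ccccc2c(=O)c1Cl`, 0.8 ug/mL

All three were tested in a functional assay on cells (Mast cell, Rattus norvegicus) for inhibition, with a stated time of 15 min; a higher number here means that more compound is needed for the effect, a lower number that less compound is needed. Compound 1 and compound 3 share a core and differ in one place: chloro in place of methyl on an aromatic carbon. That change gave a 2.0-fold higher number from compound 1 to compound 3 (0.30 log units; within the scatter), so the two are not separated by the measurement. Compound 2 has the same atoms as compound 1 joined differently; the difference between the two cores is not broken down here. Compound 2 has the lowest number of the three, and its gaps to compound 1 and to compound 3 are both beyond the scatter, so among these compounds it needs the least material for the effect.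

Compound 4, `O=C(Nc1nnn[nH]1)c1cc(=O)c2cc(Cl)ccc2o1`, has not yet been measured. It differs from compound 2 as follows: chloro in place of methyl on an aromatic carbon. Among the compounds with values here, this is the same kind of change as the one from compound 1 to compound 3, but not the same: there the chloro sat on a six-membered aromatic ring with 1 oxygen, ortho to a group of 1 heavy atom, ortho to a group of 8 heavy atoms and two atoms from the ring oxygen, whereas here it sits on a six-membered aromatic ring of carbon only. Because the earlier change gave only a 2.0-fold higher number from compound 1 to compound 3 (0.30 log units; within the scatter), compound 4 is expected to move by about a 1.6-fold higher number from compound 2 to compound 4 (0.20 log units; within the scatter). The estimate for compound 4 in this assay is 0.12 ug/mL, with a likely range from 0.04 ug/mL to 0.4 ug/mL.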

Compound 4, concentration for half-maximal effect: 0.75 ug/mL
The estimate for compound 4 lay 6.3-fold (0.80 log units) below the measured number; the whole stated range lies below it.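

On the core of compound 2, chloro in place of methyl gave a 10-fold higher number from compound 2 to compound 4 (1.00 log units; beyond the scatter) in this assay, so compound 4 needs clearly more material for the effect than compound 2. The size of this step therefore does not carry over from one core to the other, and a step read on one core is a poor guide to the same change on the other: the same change on two cores in this assay, a 2.0-fold higher number (0.30 log units; within the scatter) from compound 1 to compound 3 and a 10-fold higher number (1.00 log units; beyond the scatter) from compound 2 to compound 4, 5.0-fold (0.70 log units) apart, beyond the scatter of two such steps What these two pairs do not show is the reason for the gap, as the cores differ in where the swap sits and the data cannot separate that from any other feature of the cores, nor can two pairs give a rule for further cores in the series.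

The compounds shown leave open whether the large step on the ring of carbon only is particular to methyl and chloro, or whether a fluoro, a methoxy or an ethyl group on the same aromatic carbon would fall near compound 2 or near compound 4. They also leave open how a plain hydrogen on that carbon would compare with both groups, which would show whether methyl or chloro departs further from the unsubstituted core.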